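The source may hold more compounds than are shown below. What is called first, only, known or untested is meant among the compounds shown, and "the series" means these compounds.

Three related compounds have so far been measured in a functional assay on HUVEC cells (Homo sapiens) for antiproliferative activity (on this read-out higher numbers stand for weaker inhibition of growth and lower numbers for stronger inhibition of growth), and they sit close together. Compound 1 `CCOc1ccc(/C=C/C(=O)Nc2ccc(NC(=O)[C@@H](O)[C@H](N)CC3CCCCC3)cc2)cc1` gives 1000 nM in this test, compound 2 `COc1cc(/C=C/C(=O)Nc2ccc(NC(=O)[C@@H](O)[C@H](N)CCC3CCCCC3)cc2)cc(OC)c1OC` gives 800 nM and compound 3 `COc1cc(/C=C/C(=O)Nc2ccc(NC(=O)[C@@H](O)[C@H](N)CCc3ccccc3)cc2)cc(OC)c1OC` gives 850 nM on the same read-out. Compound 3 lies within the scatter of both others, so these three numbers cannot be told apart.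

Compound 4 `COc1cc(NC(=O)/C=C/c2cc(OC)c(OC)c(OC)c2)ccc1NC(=O)[C@@H](O)[C@H](N)CCc1ccccc1` is built from compound 3 by a single change on an aromatic ring. That change is methoxy in place of hydrogen on an aromatic carbon and in words it is methoxy in place of hydrogen on an aromatic carbon, ortho to a large group and meta to a large group.

Going by the values given here, only one measured step is available for comparison, and it swaps cyclohexyl for phenyl on the saturated chain. That step is a 1.1-fold higher number from compound 2 to compound 3 (0.03 log units; within the scatter) and it stays within the scatter, but it sits at another place in the molecule. Among the compounds with values here, no measured pair tests a methoxy on this ring, so the data offer only weak guidance.

In this assay the expected step is a 1.1-fold higher number from compound 3 to compound 4 (0.02 log units; within the scatter) and so none beyond the scatter, with no direction to favour. The estimate for compound 4 is 900 nM with an expected range of 350 nM to 2500 nM on repeated measurement.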

Compound 4, concentration for 50% growth inhibition: 700 nM
Compound 4: middle estimate off by 1.3-fold (0.11 log units), on the high side; the measured number falls inside the stated range.
By their numbers in this assay, from the lowest: compounds 4, 2, 3 and 1 (each within the scatter of the next).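

In this assay, putting a methoxy in place of hydrogen on an aromatic carbon, ortho to a large group and meta to a large group, gives a 1.2-fold lower number from compound 3 to compound 4 (0.08 log units; within the scatter), so the two numbers cannot be told apart. Going by these compounds alone, the only earlier step touched the saturated chain, whereas this one gives the first reading on the aromatic ring itself: at this carbon, a group of 2 heavy atoms with 1 hydrogen-bond acceptor can replace a bare hydrogen without moving the number beyond the usual scatter. No supporting measurement is available to explain this outcome.

The compounds shown leave open whether a different group on this same carbon, such as an amine, a carboxylic acid or a chlorine atom, would also stay within the scatter or would shift growth inhibition clearly in either direction. They also leave open whether a methoxy on the other carbons of this ring would behave the same way, and whether this result would hold with the cyclohexyl group of compound 2 on the chain.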